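This account rests on a few compounds, and the source may have more. Where it says the series, first, only, none or still open, it means among the compounds named here.

Compound 1 `COc1cc(OC)c(/C=C/S(=O)(=O)Nc2ccc(F)c(N)c2)c(OC)c1`: 10000 nM
Compound 2 `O=S(=O)(/C=C/c1c(F)c(F)c(F)c(F)c1F)Nc1c(F)c(F)c(F)c(F)c1F`: 35000 nM
Compound 3 `COc1cc(OC)c(/C=C/S(=O)(=O)Nc2ccc(OC)c(F)c2)c(OC)c1`: 200 nM

In a functional assay on DU-145 cells (Homo sapiens) for cytotoxicity, read by trypan blue exclusion, with a stated time of 96 h (a higher number here means a weaker inhibitor, a lower number a stronger inhibitor), compound 3 has the lowest number of the three. Compound 4 `COc1cc(OC)c(/C=C/S(=O)(=O)Nc2ccc(OC)c([N+](=O)[O-])c2)c(OC)c1` departs from it in one group: nitro in place of fluoro on an aromatic carbon. The new group is a nitro in place of fluoro on an aromatic carbon, ortho to a methoxy group. Going by the values given here, only one measured step bears on this, a 50-fold lower number from compound 1 to compound 3 (1.70 log units; beyond the scatter). Among the compounds with values here, it is large, but it alters more than that one group, and no measured compound carries a nitro, so it is a loose guide. A modest rise in the number is expected, well short of that step. The expected change is a 2.5-fold higher number from compound 3 to compound 4 (0.40 log units; beyond the scatter). For compound 4 the estimate is 500 nM, with an expected range of 80 nM to 4000 nM.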

Compound 4, half-maximal inhibitory concentration: 2500 nM
Compound 4: middle estimate off by 5.0-fold (0.70 log units), on the low side; the measured number falls inside the stated range.
By their numbers in this assay, from the lowest: compound 3; then compound 4; then compound 1; then compound 2.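

In this assay, the aromatic carbon ortho to a methoxy group proves sensitive to what it carries: nitro in place of fluoro gives a 13-fold higher number from compound 3 to compound 4 (1.10 log units; beyond the scatter). The earlier step to compound 3 altered more than one group, whereas this one reads a single group at this position. Nothing measured here accounts for the difference between fluoro and nitro. On these data alone, whether a chloro group, a nitrile or a hydroxyl on this carbon would give a number nearer that of compound 3 or that of compound 4 remains open.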